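Replacing the nitro-bearing aryl on the carbonyl of compound 1

The compounds below may be only part of what the source reports. "The series", "measured", "known", "first", "only" and "open" are said of these compounds alone.

Measured compounds:
- compound 1, `COc1cc(OC)c2sc(-c3ccc(N/C=C\C(=O)c4ccc(OC)c([N+](=O)[O-])c4)c(C)c3)nc2c1`: 9390 nM
- compound 2, `COc1ccc(C(=O)/C=C\Nc2ccc(-c3nc4cc(OC)c(OC)c(OC)c4s3)cc2C)cc1[N+](=O)[O-]`: 13400 nM
- compound 3, `COc1cc(OC)c2sc(-c3ccc(N/C=C\C(=O)c4ccc(OC)c([N+](=O)[O-])c4)cc3)nc2c1`: 12900 nM

The three compounds were tested in a functional assay on HeLa cells (Homo sapiens) for antiproliferative activity, read by sulforhodamine B assay, with a stated time of 48 h; on this read-out lower numbers stand for stronger inhibition and higher numbers for weaker inhibition. Compound 1 gives 9390 nM, the lowest of the three numbers, but its distance to the other two is small: a 1.4-fold higher number from compound 1 to compound 2 (0.15 log units; within the scatter), and a 1.4-fold higher number from compound 1 to compound 3 (0.14 log units; within the scatter). Both of those steps fall within the scatter, so the three compounds cannot be told apart on these data.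

Compound 4, `COc1cc(OC)c2sc(-c3ccc(N/C=C\C(=O)c4cc(OC)c(OC)c(OC)c4)c(C)c3)nc2c1`, differs from compound 1 in one place: 3,4,5-trimethoxyphenyl in place of 4-methoxy-3-nitrophenyl on a carbonyl carbon. Neither measured step bears on this change. The step from compound 1 to compound 2 adds a methoxy to the shared core, and the step from compound 1 to compound 3 removes a methyl from an aromatic carbon; both leave the aryl on the carbonyl untouched, and both were within the scatter. The change to compound 4 is larger than either and touches a part of the molecule for which no comparison exists. The expectation for compound 4 therefore rests on compound 1 alone, with a wide range and no direction supported by the data.

Compound 4 is expected to give 4000 nM in this assay, with a range from 400 nM to 20000 nM. This estimate means a 2.3-fold lower number from compound 1 to compound 4 (0.37 log units; beyond the scatter), a step that is itself expected rather than measured.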

Compound 4, half-maximal inhibitory concentration: 16400 nM
The estimate for compound 4 lay 4.1-fold (0.61 log units) below the measured number; low and high end bracket the measured number.
By their numbers in this assay, from the lowest: compounds 1, 3, 2 and 4 (each within the scatter of the next).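

Among the compounds shown here, this is the first comparison that touches the aryl on the carbonyl carbon, the one part of the molecule left unchanged in the earlier steps. In this assay, putting 3,4,5-trimethoxyphenyl in place of 4-methoxy-3-nitrophenyl gives a 1.7-fold higher number from compound 1 to compound 4 (0.24 log units; within the scatter), so these two compounds cannot be told apart, even though this change is larger than the earlier ones and removes the nitro group entirely. For this one pair, then, the nitro group is not required for a number at this level, and the aryl at this place can differ considerably with no difference that the assay can resolve, although no measurement shown here accounts for this result.

Going by these compounds, a single pair within the scatter cannot show whether this position tolerates change in general, so it remains open whether a plain phenyl, an aryl carrying an amine or a carboxylic acid, or a saturated alkyl chain on the carbonyl carbon would give a clearly different number. On these data alone, it also remains open whether 3,4,5-trimethoxyphenyl would read the same way on the cores of compound 2 and compound 3.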